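Compound 3 to compound 4: one aromatic group exchanged

This account rests on a few compounds, and the source may have more. Where it says the series, first, only, none or still open, it means among the compounds named here.

Of the compounds shown here, three sharing one core have been read in an ADME assay (liver) for metabolic stability, with Liver microsome (Homo sapiens) as the target, using microsomes and NADPH, with a stated time of 30 min, tested at 1 uM; on this read-out higher numbers stand for fast clearance and lower numbers for slow clearance. Compound 1 `COc1cc(C(O)(C(F)(F)F)C(F)(F)F)cnc1N1CCN(S(=O)(=O)c2ccc(N)nc2)CC1` carries methoxy at the varied position, and its result of < 14 mL.min-1.g-1 is a limit of the assay, not a number. Compound 2 `Nc1ccc(S(=O)(=O)N2CCN(c3ncc(C(O)(C(F)(F)F)C(F)(F)F)cc3C#CC3CC3)CC2)cn1`, carrying 2-cyclopropylethynyl there, also returns only a limit, < 14 mL.min-1.g-1. Among the measured compounds shown here, compound 3 `Cn1cc(-c2cc(C(O)(C(F)(F)F)C(F)(F)F)cnc2N2CCN(S(=O)(=O)c3ccc(N)nc3)CC2)cn1`, carrying 1-methyl-1H-pyrazol-4-yl, gives 19 mL.min-1.g-1, the only true number in the set. The comparison therefore rests largely on (the limit of < 14 mL.min-1.g-1 in this assay, at which 2 of the 3 values shown sit).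

Compound 4 `CS(=O)(=O)Nc1cccc(-c2cc(C(O)(C(F)(F)F)C(F)(F)F)cnc2N2CCN(S(=O)(=O)c3ccc(N)nc3)CC2)c1` has 3-(methanesulfonamido)phenyl in place of 1-methyl-1H-pyrazol-4-yl on an aromatic carbon, (3-(methanesulfonamido)phenyl in place of 1-methyl-1H-pyrazol-4-yl on an aromatic carbon). For the measured compounds named here, two measured steps touch this position through compound 3: an at least 1.3-fold higher number from compound 1 to compound 3 (0.13 log units; that floor lies within the scatter), and an at least 1.3-fold higher number from compound 2 to compound 3 (0.13 log units; that floor lies within the scatter). The third step, a step that the two limits leave unreadable from compound 1 to compound 2, adds no size. None of these steps is shown to exceed the scatter, and none involves the entering group, so no step beyond the scatter is expected in this assay, and no direction can be favoured. The expectation therefore stays close to compound 3 at 19 mL.min-1.g-1. The expected change is a 1.1-fold higher number from compound 3 to compound 4 (0.02 log units; within the scatter). For compound 4 the estimated value is 20 mL.min-1.g-1, with an expected range from 10 mL.min-1.g-1 to 42 mL.min-1.g-1.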

Compound 4, intrinsic clearance in microsomes: 40 mL.min-1.g-1
The estimate for compound 4 lay 2.0-fold (0.30 log units) below the measured number; the measured number falls inside the stated range.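

In this assay, among the compounds shown here, this position, on an aromatic carbon ortho to a large group, now shows a step beyond the scatter for the first time (a 2.1-fold higher number from compound 3 to compound 4 (0.32 log units; beyond the scatter)). The same entering group, 3-(methanesulfonamido)phenyl, also stands clear of the two smaller substituents, with the read-out moving towards faster clearance in both comparisons (an at least 2.8-fold higher number from compound 2 to compound 4 (0.45 log units; beyond the scatter); an at least 2.8-fold higher number from compound 1 to compound 4 (0.45 log units; beyond the scatter)). So the group carried here can shift intrinsic clearance in microsomes by more than the scatter, although these last two steps are only floors and their full size stays unknown because of a limit of the assay: (the limit of < 14 mL.min-1.g-1 in this assay, at which 2 of the 4 values shown sit).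

The compounds shown leave open whether the higher number goes with the phenyl ring itself or with the methanesulfonamido group on it, as the entering group brings both at once. A plain phenyl, or a phenyl carrying an amine or a carboxylic acid in place of the methanesulfonamido group, would separate these two parts of the change.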